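Phenyl for cyclopropylmethyl on the shared core

The source may hold more compounds than are shown below. What is called first, only, known or untested is meant among the compounds shown, and "the series" means these compounds.

In a functional assay on HeLa cells (Homo sapiens) for antiproliferative activity, read by sulforhodamine B assay (a lower number here means a stronger inhibitor of growth, a higher number a weaker inhibitor of growth), compound 1 `OC[C@@H]1O[C@H](COCc2ccccc2)[C@@H](OCc2ccccc2)[C@H](OCc2ccccc2)[C@H]1O` gives 25800 nM as a measured number. Compound 2 `O[C@@H]1[C@@H](OCc2ccccc2)[C@H](OCc2ccccc2)[C@@H](COCc2ccccc2)O[C@H]1CC1CC1` gives > 50000 nM in the same read-out, and that is a limit of the assay, not a number. Compound 2 therefore stands at the limit of > 50000 nM in this assay, at which 1 of the 2 values shown sits, with no number of its own. For the measured compounds named here, the one measured step is an at least 1.9-fold higher number from compound 1 to compound 2 (0.28 log units; that floor lies within the scatter) and it gives only a floor, with no measured step covering phenyl. Compound 3 `O[C@@H]1[C@@H](OCc2ccccc2)[C@H](OCc2ccccc2)[C@@H](COCc2ccccc2)O[C@H]1c1ccccc1` carries phenyl in place of cyclopropylmethyl on a saturated ring carbon next to the ring oxygen, with phenyl in place of cyclopropylmethyl on a saturated ring carbon as the counted change. Resting on an at least 1.9-fold higher number from compound 1 to compound 2 (0.28 log units; that floor lies within the scatter) as the only guide, no step beyond the scatter is expected in this assay and no direction can be favoured. The expected step is an at least 1.1-fold lower number from compound 2 to compound 3 (0.04 log units; that floor lies within the scatter) as a rough estimate. Compound 3 is estimated at 45000 nM with an expected range from 20000 nM to 100000 nM in this read-out.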

Compound 3, concentration for 50% growth inhibition: > 50000 nM
Compound 3: only a limit was reported; the forecaster's own chance of this, stated with the estimate: 55%; middle value at least 1.1-fold (0.04 log units) away from the limit.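

In this assay, the saturated ring carbon next to the ring oxygen now has two groups in place of hydroxymethyl, cyclopropylmethyl in compound 2 and phenyl in compound 3, and neither gives a measured number. From the compounds shown here alone, the only readable new result is an at least 1.9-fold higher number from compound 1 to compound 3 (0.28 log units; that floor lies within the scatter), so a six-membered aromatic ring at this carbon shows no step beyond the scatter, and the true size of the step remains unknown. The step between compound 2 and compound 3 cannot be read, and the two compounds stop at the same limit of the assay rather than at numbers: the limit of > 50000 nM in this assay, at which 2 of the 3 values shown sit.

Going by these compounds, what remains open is how far either group really lies from compound 1, and whether phenyl differs from cyclopropylmethyl at all. Also open, on these data alone, is how an aminomethyl group or a carboxylic acid at this carbon would read against the hydroxymethyl of compound 1.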